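Nitro substitution on two related cytotoxic quinolone cores

A few compounds are considered here, and "the series" means these few. Any claim that something is new, unique, unknown or untested is made for them only; others in the source may bear on it.

Compound 1 `CCn1cc(-c2nc3ccccc3o2)c(=O)c2cc(F)c(N3CCNC(C)C3)c(F)c21` and compound 3 `CCn1cc(-c2nc3ccc([N+](=O)[O-])cc3o2)c(=O)c2cc(F)c(N3CCNC(C)C3)c(F)c21` share one core and differ only by nitro in place of hydrogen on an aromatic carbon. In a functional assay on A2780 cells (Homo sapiens) for cytotoxicity, read by MTT assay, with a stated time of 48 h (a higher number here means a weaker inhibitor, a lower number a stronger inhibitor), compound 1 gives 83500 nM, whereas compound 3 gives 200 nM, a step of a 420-fold lower number from compound 1 to compound 3 (2.62 log units; beyond the scatter). Compound 2 `CCn1cc(-c2nc3ccccc3s2)c(=O)c2cc(F)c(N3CCNCC3)cc21` is built on a different core; how its core differs from that of compound 1 is not broken down here. In this assay compound 2 gives 11300 nM, which stands between the two values measured for the first core. Compound 4 `CCn1cc(-c2nc3ccc([N+](=O)[O-])cc3s2)c(=O)c2cc(F)c(N3CCNCC3)cc21` has not yet been measured and differs from compound 2 by nitro in place of hydrogen on an aromatic carbon, the same kind of change that turns compound 1 into compound 3. Within the data shown here, a large step in this assay is expected from this change on the second core as well, resting on the single measured pair, where the step from compound 1 to compound 3 was a 420-fold lower number from compound 1 to compound 3 (2.62 log units; beyond the scatter). The expected step is a 110-fold lower number from compound 2 to compound 4 (2.05 log units; beyond the scatter), set somewhat smaller because compound 2 already starts from 11300 nM. Compound 4 is therefore estimated at 100 nM, most likely between 15 nM and 800 nM.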

Compound 4, half-maximal inhibitory concentration: 700 nM
For compound 4 the middle estimate is 7.0-fold (0.85 log units) below the measured one, and the stated range covers the measured number.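

On the second core the nitro change again lowers the number in this assay, with a 16-fold lower number from compound 2 to compound 4 (1.21 log units; beyond the scatter), so the direction of the step carries over from the core of compound 1 to the core of compound 2. The size of the step does not carry over, and the two steps differ clearly: the same change on two cores in this assay, a 420-fold lower number (2.62 log units; beyond the scatter) from compound 1 to compound 3 and a 16-fold lower number (1.21 log units; beyond the scatter) from compound 2 to compound 4, 26-fold (1.41 log units) apart, beyond the scatter of two such steps The two cores differ in more than one place, so these two pairs cannot tie the gap to any single structural difference, nor can they show how large the step would be on a further core.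

The compounds shown leave open whether an amine or a nitrile in place of the nitro group would also lower the number on either core. On these data alone, it also remains open how the step would behave with the nitro group on a different aromatic carbon of the same six-membered ring.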